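This account rests on a few compounds, and the source may have more. Where it says the series, first, only, none or still open, it means among the compounds named here.

Working notes on the series. In a functional assay on PC-3 cells (Homo sapiens) for inhibition, read by MTT assay, with a stated time of 48 h (a higher number here means a weaker inhibitor, a lower number a stronger inhibitor), compound 1 `COc1cc(N(Cc2ccc(F)cc2)S(=O)(=O)c2ccc(C)cc2)cc(OC)c1OC` gives 20700 nM, compound 2 `COc1cc(N(Cc2cccc(C)c2)S(=O)(=O)c2ccc(C)cc2)cc(OC)c1OC` gives 8580 nM and compound 3 `COc1cc(N(Cc2nc3ccccc3[nH]2)S(=O)(=O)c2ccc(C)cc2)cc(OC)c1OC` gives 3340 nM, the lowest of the three numbers. Compound 4 `COc1cc(N(Cc2nc3ccccc3[nH]2)C(=O)c2cccc(Cl)c2)cc(OC)c1OC` keeps the 1H-benzimidazol-2-yl group of compound 3 and carries (3-chlorophenyl)carbonyl in place of (4-methylphenyl)sulfonyl on a nitrogen on an aromatic ring.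

The measured steps all lie at another place, on a saturated chain carbon bound to a sulfonamide nitrogen: a 2.4-fold lower number from compound 1 to compound 2 (0.38 log units; beyond the scatter), a 6.2-fold lower number from compound 1 to compound 3 (0.79 log units; beyond the scatter) and a 2.6-fold lower number from compound 2 to compound 3 (0.41 log units; beyond the scatter). Each is modest and beyond the scatter, but none of them exchanges the (4-methylphenyl)sulfonyl group. They bear on the new change only indirectly, as a guide to how far one exchange has moved the numbers in this small set. Among the measured compounds shown here, no measured compound carries a carbonyl at this nitrogen, so the data give no direction. In this assay, from the compounds shown here alone, no step beyond the scatter is therefore expected, with the caveat that a modest move either way remains open. The expected change is a 1.2-fold higher number from compound 3 to compound 4 (0.08 log units; within the scatter). For compound 4 the estimated value is 4000 nM, with an expected range of 1100 nM to 15000 nM.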

Compound 4, half-maximal inhibitory concentration: > 50000 nM
Compound 4 gave a limit, no number; the forecaster's own chance of this, stated with the estimate: 10%; middle value at least 12-fold (1.09 log units) away from the limit.
By their numbers in this assay, from the lowest: compound 3; then compound 2; then compound 1. At a limit, above all of these: compound 4.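

Compound 4 gives a limit of the assay and not a number: the limit of > 50000 nM in this assay, at which 1 of the 4 values shown sits. In this assay, among the compounds shown here, the exchange of (4-methylphenyl)sulfonyl for (3-chlorophenyl)carbonyl on a nitrogen on an aromatic ring gives an at least 14-fold higher number from compound 3 to compound 4 (1.17 log units; beyond the scatter), a large step, whereas the earlier steps, all on the saturated chain carbon, were modest. This shows that the group on this nitrogen can move the number further than any exchange shown on the chain carbon, and that keeping the 1H-benzimidazol-2-yl group of compound 3 does not by itself hold the number of compound 3 in compound 4.

The step joins two changes in one exchange, the carbonyl for the sulfonyl and the 3-chlorophenyl for the 4-methylphenyl, and the compounds shown do not separate them. Still open, from the compounds shown here alone, is where a (3-chlorophenyl)sulfonyl group, a (4-methylphenyl)carbonyl group or a plain acetyl group on this nitrogen would fall, and so whether the carbonyl link or the substituted phenyl ring goes with the step.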